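The source may report more compounds than this note shows. Statements on the series, on what has been measured and on what is new or still open speak of the compounds shown alone.

Notes on the series. Compound 1 `COc1ccc(-c2cc(/C=C/C(=O)c3cc(OC)c(OC)c(OC)c3)[nH]n2)cc1OC` and compound 2 `COc1ccc(C(=O)/C=C/c2cc(-c3cc(OC)c(OC)c(OC)c3)n[nH]2)cc1` share their core with compound 3 `COc1ccc(C(=O)/C=C/c2cc(-c3cc(OC)c(OC)c(OC)c3)n[nH]2)cc1OC`, and all three have been run in a functional assay on NCI-H322M cells (Homo sapiens) for inhibition, read by sulforhodamine B assay, with a stated time of 48 h; a lower number here means a stronger inhibitor of growth, a higher number a weaker inhibitor of growth. Compound 1 gives 6030 nM, compound 2 gives 4070 nM, and compound 3 gives 2900 nM. Compound 3 thus stands at the lowest of the three numbers shown, though compound 2 is within the scatter of it: the step of a 1.4-fold lower number from compound 2 to compound 3 (0.15 log units; within the scatter) does not rise above the usual spread, whereas compound 1 sits a little beyond the scatter from compound 3.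

Compound 4 `COc1cc(C(=O)/C=C/c2cc(-c3cc(OC)c(OC)c(OC)c3)n[nH]2)cc(OC)c1OC` is the next member and has not yet been measured in this assay. It differs from compound 3 by methoxy in place of hydrogen on an aromatic carbon. Going by the values given here, the only measured step of the same kind, methoxy in place of hydrogen on an aromatic carbon, is the one from compound 2 to compound 3, and that step stayed within the scatter. On that basis no step beyond the scatter is expected in this assay; if anything, a modest move toward a lower number.

Compound 4 is therefore expected to give 2500 nM, with a range of 1000 nM to 6000 nM. The expected step of a 1.2-fold lower number from compound 3 to compound 4 (0.06 log units; within the scatter) is small. A measurement will settle the point.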

Compound 4, concentration for total growth inhibition: 4850 nM
The estimate for compound 4 lay 1.9-fold (0.29 log units) below the measured number; low and high end bracket the measured number.
By their numbers in this assay, from the lowest: compounds 3, 2, 4 and 1 (each within the scatter of the next, the first and the last beyond it).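

In this assay, methoxy in place of hydrogen at this position, ortho to a methoxy group and meta to a large group, gives a 1.7-fold higher number from compound 3 to compound 4 (0.22 log units; within the scatter), so filling this place on the ring does not carry the number past the scatter. Read on a different core, the same change gives a 1.2-fold lower number from compound 1 to compound 4 (0.09 log units; within the scatter), and this step also stays within the scatter. All three steps of this kind now shown stay within the scatter, and the two that compare this change across cores agree: the same change on two cores in this assay, a 1.4-fold lower number (0.15 log units; within the scatter) from compound 2 to compound 3 and a 1.2-fold lower number (0.09 log units; within the scatter) from compound 1 to compound 4, 1.1-fold (0.05 log units) apart, within the scatter of two such steps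

The compounds shown carry only hydrogen or methoxy at this position, so the outcome with a hydroxyl, a fluorine, an amine or a longer chain such as ethoxy in that place remains open. Also open, from the compounds shown here alone, is whether any replacement on this ring can move the number beyond the scatter, and whether the same flat reading holds in cell lines other than this one.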